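A few compounds are considered here, and "the series" means these few. Any claim that something is new, unique, unknown or untested is made for them only; others in the source may bear on it.

Measured so far:
compound 1, `O=C(Nc1ccc(Oc2ccnc3[nH]ccc23)cc1)c1nn(-c2ccc(Br)cc2)ccc1=O`, 7890 nM in a functional assay on MCF7 cells (Homo sapiens) for cytotoxicity, read by MTT assay, with a stated time of 72 h; on this read-out higher numbers stand for weaker inhibition and lower numbers for stronger inhibition;
compound 2, `O=C(Nc1ccc(Oc2ccnc3[nH]ccc23)c(F)c1)c1nn(-c2ccc(Br)cc2)ccc1=O`, 11600 nM in this assay.

Compound 2 has the higher of these two numbers, but the gap to compound 1, a 1.5-fold higher number from compound 1 to compound 2 (0.17 log units; within the scatter), is within the scatter, so the two cannot be told apart. Compound 3, `O=C(Nc1ccc(Oc2ccnc3[nH]ccc23)c(F)c1)c1nn(-c2ccc(Cl)c(C(F)(F)F)c2)ccc1=O`, is the next compound. It keeps the shared core of compound 2 and changes only the group on the aromatic nitrogen: 4-chloro-3-(trifluoromethyl)phenyl in place of 4-bromophenyl on an aromatic nitrogen. Among the compounds with values here, no measured step touches this part of the molecule; the one step known, from compound 1 to compound 2, concerns a different ring and was itself within the scatter. There is therefore nothing in hand to predict a shift in this assay in either direction, and no step beyond the scatter is expected. Compound 3 is expected to give about 10000 nM, somewhere between 3000 nM and 35000 nM, an expected step of a 1.2-fold lower number from compound 2 to compound 3 (0.06 log units; within the scatter).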

Compound 3, half-maximal inhibitory concentration: 11600 nM
Beside the measured number, compound 3's estimate is 1.2-fold (0.06 log units) below it, and the stated range covers the measured number.
By their numbers in this assay, from the lowest: compounds 1, 2 and 3 (each within the scatter of the next).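

Within the data shown here, putting 4-chloro-3-(trifluoromethyl)phenyl in place of 4-bromophenyl on the aromatic nitrogen gives no change at the digits printed from compound 2 to compound 3 (within the scatter) in this assay and is the first measured step at this position. The earlier step concerned a different ring, whereas this one shows that a group of 11 heavy atoms and one of 7 cannot be told apart here, at least for this pair of phenyl groups. No measurement at hand gives a reason for this result.

On these data alone, both groups seen at this position are halogen-bearing phenyl rings, so it remains open whether a group of another kind, such as a simple methyl, a carboxylic acid or an amine on a short chain, would shift the number beyond the scatter. Also open, as far as these compounds go, is whether the same swap reads alike on the core of compound 1, which lacks the fluoro group.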